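Swapping the benzyl group of a diamino quinoxaline

This account rests on a few compounds, and the source may have more. Where it says the series, first, only, none or still open, it means among the compounds named here.

Measured compounds:
- compound 1 `Nc1cc(N)c2nc(-c3ccccc3)c(NCc3ccc(Cl)c(Cl)c3)nc2c1`: < 100000 nM
- compound 2 `CCOC(=O)[C@H](CCC(=O)O)NC(=O)c1ccc(Sc2nc3cc(N)cc(N)c3nc2-c2ccccc2)cc1`: < 100000 nM

In a functional assay on MDA-MB-231 cells (Homo sapiens) for inhibition, read by sulforhodamine B assay, with a stated time of 48 h (a higher number here means that more compound is tolerated, a lower number that less compound is tolerated), compound 1 gives < 100000 nM, which is a limit of the assay, not a number. Compound 2 likewise reaches only a limit, < 100000 nM. Both values sit at the same boundary, as the limit of < 100000 nM in this assay, at which 2 of the 2 values shown sit, records, so no ordering between them can be read. Compound 3 `COc1ccc(CNc2nc3cc(N)cc(N)c3nc2-c2ccccc2)cc1` carries 4-methoxyphenyl in place of 3,4-dichlorophenyl on a saturated chain carbon bound to a nitrogen on an aromatic ring. Going by the values given here, with no measured step to lean on, compound 3 is expected to differ from compound 1 by a step that the limit leaves unreadable from compound 1 to compound 3, not beyond the scatter, and compound 3 is estimated at 30000 nM (range 3000 nM to 100000 nM).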

Compound 3, concentration lethal to 50% of the cells: 64600 nM
For compound 3 the middle estimate is 2.2-fold (0.33 log units) below the measured one; the range from low to high includes it.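

The step from compound 1 to compound 3 cannot be read, because compound 1 stands only at a limit: the limit of < 100000 nM in this assay, at which 2 of the 3 values shown sit.

The compounds shown leave open how the 3,4-dichlorobenzyl and 4-methoxybenzyl groups actually compare on the shared core.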